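Acetyl to hydrogen on compound 1: working notes

The source may report more compounds than this note shows. Statements on the series, on what has been measured and on what is new or still open speak of the compounds shown alone.

For the measured compounds named here, in a functional assay on HCT-116 cells (Homo sapiens) for cytotoxicity (on this read-out higher numbers stand for weaker inhibition and lower numbers for stronger inhibition), compound 1 (`COC(=O)/C=C/c1oc(=O)c(COC(C)=O)c(OC)c1CO`) gives 2310 nM, the only numeric value so far. Compound 2 (`COc1c(C)c(/C=C/C(=O)O)oc(=O)c1CO`) gives only a limit of the assay, > 50000 nM. Compound 1 is therefore the sole numeric reference point.

Compound 3 (`COC(=O)/C=C/c1oc(=O)c(CO)c(OC)c1CO`) has not yet been measured. Its difference from compound 1 is hydrogen in place of acetyl on an oxygen on a saturated carbon, which is hydrogen in place of acetyl on an oxygen on a saturated carbon, so that acetoxymethyl becomes hydroxymethyl. Going by the values given here, no step between measured compounds is available to calibrate this change, and the expectation is correspondingly loose. A modest weakening in this assay is expected, slightly beyond the usual scatter, with a fall to the limit of the assay thought unlikely. The estimated change is a 2.6-fold higher number from compound 1 to compound 3 (0.41 log units; beyond the scatter). Compound 3 is estimated at 6000 nM, with an expected range from 1500 nM to 30000 nM.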

Compound 3, half-maximal inhibitory concentration: > 50000 nM
Compound 3: a limit, no number; the forecaster's own chance of this, stated with the estimate: 10%; middle value at least 8.3-fold (0.92 log units) away from the limit.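

For the compounds shown here, the first step that can be read falls on the acetoxymethyl group, and in this assay hydroxymethyl in its place gives an at least 21-fold higher number from compound 1 to compound 3 (1.33 log units; beyond the scatter), so this single change on an oxygen on a saturated carbon is enough to carry the series from its only numeric value to a limit. With the rest of the core unchanged, the acetyl on this oxygen is needed to keep a measurable value in this assay. Compound 3 gives > 50000 nM, which is a limit of the assay and not a number, so the step is only a lower bound and its full size cannot be read: the limit of > 50000 nM in this assay, at which 2 of the 3 values shown sit.

The compounds shown leave open whether another group on this oxygen, such as a propanoyl ester, a benzoyl ester or a methyl ether, would hold the value that compound 1 gives, 2310 nM, or whether acetyl alone does so. Also open, going by these compounds, is whether the other hydroxymethyl group, common to compound 1 and compound 3, would respond in the same way to acetyl in place of its hydrogen.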